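A few compounds are considered here, and "the series" means these few. Any claim that something is new, unique, unknown or untested is made for them only; others in the source may bear on it.

Compound 1 `c1ccc(CSc2nnc(-c3ccc4c(c3)OCCO4)n2-c2ccccc2)cc1` is measured in a functional assay on BGC-823 cells (Homo sapiens) for antiproliferative activity, read by MTT assay, with a stated time of 24 h (on this read-out higher numbers stand for weaker inhibition and lower numbers for stronger inhibition), at 73400 nM. Compound 2 `O=[N+]([O-])c1ccc(CSc2nnc(-c3ccc4c(c3)OCCO4)n2-c2ccccc2)cc1` gives 48600 nM, and the step of a 1.5-fold lower number from compound 1 to compound 2 (0.18 log units; within the scatter) lies within the scatter, so compound 1 stands beside compound 2 with no order between them. Compound 3 `COc1cccc(CSc2nnc(-c3ccc4c(c3)OCCO4)n2-c2ccccc2)c1` reports only a limit in this assay, > 100000 nM, and the limit of > 100000 nM in this assay, at which 1 of the 3 values shown sits, sets the floor on what that step can be. The step of an at least 1.3-fold higher number from compound 1 to compound 3 (0.13 log units; that floor lies within the scatter) still sits within the scatter, whereas an at least 2.0-fold higher number from compound 2 to compound 3 (0.31 log units; beyond the scatter) is beyond it.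

Compound 4 `Fc1ccc(CSc2nnc(-c3ccc4c(c3)OCCO4)n2-c2ccccc2)c(F)c1` differs from compound 1 in that (2,4-difluorophenyl in place of phenyl on a saturated chain carbon bound to a sulfur). The two measured steps that bear on this change, both substitutions on the same benzyl phenyl, are a 1.5-fold lower number from compound 1 to compound 2 (0.18 log units; within the scatter) and an at least 1.3-fold higher number from compound 1 to compound 3 (0.13 log units; that floor lies within the scatter); neither exceeds the scatter. No step beyond the scatter is therefore expected in this assay for compound 4, in either direction. The expected step is a 1.0-fold lower number from compound 1 to compound 4 (0.02 log units; within the scatter). The estimate for compound 4 is 70000 nM, expected to lie between 30000 nM and 150000 nM.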

Compound 4, half-maximal inhibitory concentration: > 100000 nM
Compound 4 ended at the assay's limit; the forecaster's own chance of this, stated with the estimate: 30%; at least 1.4-fold (0.15 log units) between middle value and limit.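

In this assay, for the compounds shown here, compound 4 also reads only as a limit, > 100000 nM, and limits now recur: the limit of > 100000 nM in this assay, at which 2 of the 4 values shown sit. The step of an at least 1.3-fold higher number from compound 1 to compound 4 (0.13 log units; that floor lies within the scatter) leaves 2,4-difluorophenyl not separated from phenyl on the saturated chain carbon bound to a sulfur, while the step of an at least 2.0-fold higher number from compound 2 to compound 4 (0.31 log units; beyond the scatter) sets 2,4-difluorophenyl apart from 4-nitrophenyl there, the first fluorine-bearing change to do so. The step from compound 3 to compound 4 cannot be read, since both values are limits.

From the compounds shown here alone, how far the true values of compound 3 and compound 4 lie past the limit remains unknown. Going by these compounds, it also remains open whether an amine or a carboxylic acid on this phenyl, or a longer chain in place of the benzyl group, would give a number clearly lower than that of compound 2, 48600 nM.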